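Hydroxymethyl added to the amide chain of compound 3

The source may hold more compounds than are shown below. What is called first, only, known or untested is meant among the compounds shown, and "the series" means these compounds.

Values in a functional assay on BXPC-3 cells (Homo sapiens) for antiproliferative activity, read by MTT assay, with a stated time of 24 h; on this read-out lower numbers stand for stronger inhibition and higher numbers for weaker inhibition:
- compound 1 `CCN(CC)CCNC(=O)c1ccc(C(CC)(CC)c2ccc(OCS(=O)(=O)c3ccccc3)c(C)c2)n1CC`: 6270 nM
- compound 2 `CCn1c(C(=O)N[C@@H](CO)C(C)C)ccc1C(CC)(CC)c1ccc(OCS(=O)(=O)c2ccccc2)c(C)c1`: 13200 nM
- compound 3 `CCn1c(C(=O)NCCCO)ccc1C(CC)(CC)c1ccc(OCS(=O)(=O)c2ccccc2)c(C)c1`: 26600 nM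

Compound 3 stands at 26600 nM, level within the scatter with compound 2 and clearly weaker than compound 1. Compound 4 `CCn1c(C(=O)N[C@@H](CO)CCO)ccc1C(CC)(CC)c1ccc(OCS(=O)(=O)c2ccccc2)c(C)c1` differs from compound 3 by hydroxymethyl in place of hydrogen on a saturated chain carbon bound to an amide-type nitrogen and a saturated chain carbon.

Going by the values given here, the closest precedent is a 2.0-fold higher number from compound 2 to compound 3 (0.30 log units; within the scatter), an exchange between two hydroxy-substituted amide chains. The larger 4.2-fold higher number from compound 1 to compound 3 (0.63 log units; beyond the scatter) and the modest 2.1-fold higher number from compound 1 to compound 2 (0.32 log units; beyond the scatter) both lose the diethylamino group, which compound 3 already lacks, so they bear on this change only weakly. No step beyond the scatter is therefore expected in this assay, with any drift towards a lower number. The expected change is a 1.3-fold lower number from compound 3 to compound 4 (0.12 log units; within the scatter). The estimate for compound 4 is 20000 nM, with an expected range of 9000 nM to 45000 nM.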

Compound 4, half-maximal inhibitory concentration: > 50000 nM
Compound 4 was reported as a limit (the forecaster's own chance of this, stated with the estimate: 10%); middle value at least 2.5-fold (0.39 log units) away from the limit.
By their numbers in this assay, from the lowest: compound 1; then compounds 2 and 3 (each within the scatter of the next). At a limit, above all of these: compound 4.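

In this assay compound 4 gives > 50000 nM, which is a limit and not a number. Hydroxymethyl in place of hydrogen on this saturated chain carbon brings no gain, yet the floor of an at least 1.8-fold higher number from compound 3 to compound 4 (0.27 log units; that floor lies within the scatter) does not by itself establish a loss. The gaps to the other two amides are clear: an at least 3.7-fold higher number from compound 2 to compound 4 (0.57 log units; beyond the scatter), and an at least 7.9-fold higher number from compound 1 to compound 4 (0.90 log units; beyond the scatter).

Going by these compounds, whether a primary amine, a carboxylic acid or a longer chain on this carbon would fare better stays open. On these data alone, the actual value of compound 4 also stays open.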